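This account rests on a few compounds, and the source may have more. Where it says the series, first, only, none or still open, it means among the compounds named here.

In a functional assay on DU-145 cells (Homo sapiens) for antiproliferative activity, read by propidium iodide staining, with a stated time of 96 h (on this read-out higher numbers stand for weaker inhibition and lower numbers for stronger inhibition), three compounds have been measured. Compound 1 (`CC(O)(CSc1ccc(S(F)(F)(F)(F)F)cc1)C(=O)Nc1ccc([N+](=O)[O-])c(C(F)(F)F)c1`) gives 13900 nM, compound 2 (`CC(O)(CSc1ccc(S(F)(F)(F)(F)F)cc1)C(=O)Nc1ccc(C#N)cc1C(F)(F)F`) gives 17700 nM, and compound 3 (`CC(O)(CSc1ccc(F)cc1)C(=O)Nc1ccc(S(F)(F)(F)(F)F)cc1`) gives 25400 nM. These values lie within the scatter of one another, so compound 3 cannot be told apart from the other two. Compound 4 (`CC(O)(CSc1ccccc1C(F)(F)F)C(=O)Nc1ccc(S(F)(F)(F)(F)F)cc1`) carries 2-(trifluoromethyl)phenyl in place of 4-fluorophenyl on a sulfur. Among the compounds with values here, no measured pair shows what a change of this kind does, so no shift beyond the scatter is expected in this assay, in either direction. The expected step is a 1.3-fold lower number from compound 3 to compound 4 (0.13 log units; within the scatter). For compound 4 the estimated value is 19000 nM, with an expected range of 8500 nM to 42000 nM.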

Compound 4, half-maximal inhibitory concentration: 15800 nM
Compound 4: middle estimate off by 1.2-fold (0.08 log units), on the high side; low and high end bracket the measured number.
By their numbers in this assay, from the lowest: compounds 1, 4, 2 and 3 (each within the scatter of the next).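

In this assay the sulfur position now has its first measured step: 2-(trifluoromethyl)phenyl in place of 4-fluorophenyl gives a 1.6-fold lower number from compound 3 to compound 4 (0.21 log units; within the scatter). The two aryl groups therefore cannot be told apart here, even though the entering group has more heavy atoms. No available evidence bears on this result. Still open, from the compounds shown here alone, is whether a non-aromatic group on the sulfur, such as a butyl chain or one ending in a carboxylic acid, would give a step beyond the scatter.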